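This account rests on a few compounds, and the source may have more. Where it says the series, first, only, none or still open, it means among the compounds named here.

Measured compounds in a functional assay on A549 cells (Homo sapiens) for inhibition, read by sulforhodamine B assay, with a stated time of 48 h; a higher number here means a weaker inhibitor, a lower number a stronger inhibitor:
Compound 1 `O=C(Nc1ccc(C(=O)NO)cc1)Nc1ccc(Cl)c(C(F)(F)F)c1`: 7200 nM
Compound 2 `O=C(/C=C/c1ccc(NC(=O)Nc2ccc(Cl)c(C(F)(F)F)c2)cc1)NO`: 3400 nM
Compound 3 `O=C(/C=C/c1ccc(CN2CCc3cc(NC(=O)Nc4ccc(Cl)c(C(F)(F)F)c4)ccc32)cc1)NO`: 2700 nM

Compound 4 `O=C(Nc1ccc2c(c1)CCN2Cc1ccc(C(=O)NO)cc1)Nc1ccc(Cl)c(C(F)(F)F)c1` has not yet been measured in this assay. Compound 1 and compound 2 share a core and differ only at one position: hydroxycarbamoyl in place of 2-(hydroxycarbamoyl)ethenyl on an aromatic carbon. This change gave a 2.1-fold higher number from compound 2 to compound 1 (0.33 log units; beyond the scatter). Compound 3 carries a larger core; the difference between the core of compound 3 and the core of compound 2 is not broken down here. Compound 3 and compound 2 give numbers within the scatter of each other, so no order between them can be drawn, while the number for compound 1 lies beyond the scatter from that of compound 3.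

From compound 3 to compound 4 the same change is made: hydroxycarbamoyl in place of 2-(hydroxycarbamoyl)ethenyl on an aromatic carbon. Among the measured compounds shown here, since the one measured instance of this change, from compound 2 to compound 1, moved the number by a 2.1-fold higher number from compound 2 to compound 1 (0.33 log units; beyond the scatter), a step of similar size is expected here, that is a 2.0-fold higher number from compound 3 to compound 4 (0.31 log units; beyond the scatter). This rests on a single pair, so the range is kept wide. Compound 4 is therefore estimated to give 5500 nM, with a likely span from 2700 nM to 12000 nM.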

Compound 4, half-maximal inhibitory concentration: 3100 nM
The estimate for compound 4 lay 1.8-fold (0.25 log units) above the measured number, within the range that was stated.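

In this assay, putting hydroxycarbamoyl in place of 2-(hydroxycarbamoyl)ethenyl on the larger core gave a 1.1-fold higher number from compound 3 to compound 4 (0.06 log units; within the scatter), so on that core the change produced no readable difference. Set beside the step on the smaller core, this result does not show that the change behaves differently on the two cores: the same change on two cores in this assay, a 2.1-fold higher number (0.33 log units; beyond the scatter) from compound 2 to compound 1 and a 1.1-fold higher number (0.06 log units; within the scatter) from compound 3 to compound 4, 1.8-fold (0.27 log units) apart, within the scatter of two such steps The two pairs are compatible with a small step that carries from one core to the other, but they fix neither its size nor its direction, and they do not show how the change would read on any further core.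

The compounds shown leave open how a saturated ethyl link or a longer chain between the aromatic ring and the hydroxycarbamoyl would read on either core. They also leave open what a carboxylic acid or a primary amide in place of the hydroxycarbamoyl would give in this assay.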